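Shortening a Benzyl to a Phenyl on a Weak Cytotoxic Series

The source may report more compounds than this note shows. Statements on the series, on what has been measured and on what is new or still open speak of the compounds shown alone.

Of the compounds shown here, two sharing one core have been measured so far. Compound 1 `Cc1nc(N(C)Cc2ccccc2)nc(-n2ccnc2C)c1[N+](=O)[O-]` carries a benzyl group alongside a methyl on a nitrogen attached to the core. In a functional assay on Jurkat cells (Homo sapiens) for cytotoxicity (on this read-out lower numbers stand for stronger inhibition and higher numbers for weaker inhibition), compound 1 gives 25000 nM, the lower of the two numbers recorded and therefore the stronger inhibitor of the pair. Compound 2 `Cc1nc(NC2CCc3ccccc32)nc(-n2ccnc2C)c1[N+](=O)[O-]` replaces that nitrogen substitution with a bicyclic amine; in this assay compound 2 gives 100000 nM, a number higher than that of compound 1 by more than the usual scatter, so compound 2 is clearly the weaker of the two.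

Compound 3 `Cc1nc(N(C)c2ccccc2)nc(-n2ccnc2C)c1[N+](=O)[O-]` has not yet been tested. It differs from compound 1 in one place: phenyl in place of benzyl on a nitrogen on an aromatic ring. Among the compounds with values here, no measured pair shows what such a change does, so the expectation rests only on the two numbers above, both of which describe weak inhibition. The step from compound 1 to compound 3 is expected to be small, at most modest in the direction of weaker inhibition, and possibly within the scatter: a 1.4-fold higher number from compound 1 to compound 3 (0.15 log units; within the scatter). Compound 3 is estimated to give 35000 nM in this assay, with a plausible range from 10000 nM to 100000 nM.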

Compound 3, half-maximal inhibitory concentration: 80000 nM
Beside the measured number, compound 3's estimate is 2.3-fold (0.36 log units) below it; low and high end bracket the measured number.
By their numbers in this assay, from the lowest: compound 1; then compounds 3 and 2 (each within the scatter of the next).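

In this assay, the position on the nitrogen turns out to be sensitive to this small change: replacing benzyl with phenyl gives a 3.2-fold higher number from compound 1 to compound 3 (0.51 log units; beyond the scatter). The two groups have the same kind of six-membered aromatic ring of carbon only, and neither has any hydrogen-bond donors or acceptors, so the measured loss comes with a change that leaves those counted features the same. This single step shows that, on this core, benzyl gives stronger inhibition than phenyl, although compound 1 at 25000 nM is still a weak inhibitor, and nothing available explains the difference.

From the compounds shown here alone, one step cannot show whether the trend continues in the other direction, so it remains open whether a longer chain such as phenylethyl on the same nitrogen would give a lower number than benzyl or a higher one. Going by these compounds, it is also open how much the methyl on that nitrogen contributes, and whether a ring carrying an amine or a carboxylic acid would be tolerated in place of the benzyl group.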